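Working notes: bromo in place of methoxy

The source may report more compounds than this note shows. Statements on the series, on what has been measured and on what is new or still open speak of the compounds shown alone.

In a functional assay on PC-3 cells (Homo sapiens) for antiproliferative activity, read by MTT assay, with a stated time of 72 h (a lower number here means a stronger inhibitor, a higher number a weaker inhibitor), compound 1 `CCOC(=O)c1csc2nc(CN3CCN(C)CC3)c(-c3ccc(C)cc3)n12` gives 65000 nM. Compound 2 `CCOC(=O)c1csc2nc(CN3CCN(C)CC3)c(-c3ccc(OC)cc3)n12` gives 69400 nM, which leaves it level with compound 1 within the scatter. Among the compounds with values here, these are the only two numbers so far.

Next in line is compound 3 `CCOC(=O)c1csc2nc(CN3CCN(C)CC3)c(-c3ccc(Br)cc3)n12`, with bromo in place of methoxy on an aromatic carbon, para to a large group: bromo in place of methoxy on an aromatic carbon. The same difference reads 4-methoxyphenyl to 4-bromophenyl.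

Within the data shown here, only one measured step bears on this place, methoxy in place of methyl, and it amounts to a 1.1-fold higher number from compound 1 to compound 2 (0.03 log units; within the scatter). That single step stays within the scatter, but bromo has not yet been measured on the shared core, so the evidence is thin and the range must stay wide. No step beyond the scatter is therefore expected in this assay, and no direction can be argued from these data. The expected change is a 1.1-fold lower number from compound 2 to compound 3 (0.05 log units; within the scatter). For compound 3 the estimated value is 62000 nM, with an expected range of 30000 nM to 120000 nM.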

Compound 3, half-maximal inhibitory concentration: 85000 nM
For compound 3 the middle estimate is 1.4-fold (0.14 log units) below the measured one, within the range that was stated.
By their numbers in this assay, from the lowest: compounds 1, 2 and 3 (each within the scatter of the next).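

Bromo in place of methoxy on an aromatic carbon gives a 1.2-fold higher number from compound 2 to compound 3 (0.09 log units; within the scatter) in this assay and bromo in place of methyl gives a 1.3-fold higher number from compound 1 to compound 3 (0.12 log units; within the scatter) in the same read-out, so methyl, methoxy and bromo all stand level at this place, para to a large group. The earlier pair covered only methyl and methoxy, whereas this exchange takes out the methoxy oxygen with its single hydrogen-bond acceptor, replaces two heavy atoms with one, and still produces no step beyond the scatter. No supporting data bear on why these three groups read alike.

As far as these compounds go, whether a group such as an amine, a carboxylic acid or a longer chain at this same place would leave the number level with these three remains open. Also open, from the compounds shown here alone, is whether a change elsewhere on the shared core, such as a carboxylic acid in place of the ethyl ester, would produce any step beyond the scatter in this assay or whether the series stays at this level.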